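Methyl for Chloro, Repeated on a Second Core

A few compounds are considered here, and "the series" means these few. Any claim that something is new, unique, unknown or untested is made for them only; others in the source may bear on it.

Measured compounds:
compound 1 `Cc1ccc2nc(Cl)c(/C=C/C(=O)c3ccc(Cl)s3)cc2c1`: 59.4 nM
compound 2 `Cc1cccc2cc(/C=C/C(=O)c3ccc(Cl)s3)c(Cl)nc12`: 116 nM
compound 3 `Cc1ccc2nc(Cl)c(/C=C/C(=O)c3ccc(C)s3)cc2c1`: 128 nM

Of the compounds shown here, three have been tested in a functional assay on HUVEC cells (Homo sapiens), read by BrdU incorporation, with a stated time of 72 h; on this read-out higher numbers stand for weaker inhibition and lower numbers for stronger inhibition. Compound 1 gives 59.4 nM, compound 2 gives 116 nM and compound 3 gives 128 nM. Compound 1 and compound 2 contain the same atoms joined differently; the difference between their two cores is not broken down here. Compound 3 is made from compound 1 by one change, (methyl in place of chloro on an aromatic carbon), and in this assay this brought a 2.2-fold higher number from compound 1 to compound 3 (0.33 log units; beyond the scatter).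

Compound 4 `Cc1ccc(C(=O)/C=C/c2cc3cccc(C)c3nc2Cl)s1` has not yet been measured. It is made from compound 2 by methyl in place of chloro on an aromatic carbon, which is the same change at the same kind of place as that from compound 1 to compound 3. Among the compounds with values here, the only guide is that single measured pair, so the expectation is that compound 4 shows a step of about a 2.2-fold higher number from compound 2 to compound 4 (0.33 log units; beyond the scatter) in this assay, because the same change gave a 2.2-fold higher number from compound 1 to compound 3 (0.33 log units; beyond the scatter). On that basis compound 4 is estimated at 250 nM in this assay, expected to fall between 120 nM and 520 nM.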

Compound 4, half-maximal inhibitory concentration: 145 nM
Estimate against measurement, compound 4: 1.7-fold (0.24 log units) above; low and high end bracket the measured number.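

On the core of compound 2, replacing 5-chlorothiophen-2-yl with 5-methylthiophen-2-yl gives, in this assay, a 1.3-fold higher number from compound 2 to compound 4 (0.10 log units; within the scatter), a step too small to count as a real change on its own. Set beside the earlier step, the result does not separate the two cores, as the gap between the steps is no larger than repeated measurements could produce: the same change on two cores in this assay, a 2.2-fold higher number (0.33 log units; beyond the scatter) from compound 1 to compound 3 and a 1.3-fold higher number (0.10 log units; within the scatter) from compound 2 to compound 4, 1.7-fold (0.24 log units) apart, within the scatter of two such steps. Within the data shown here, this fits a change that carries over from one core to the other, but with only two pairs, one step beyond the scatter and one within it, it does not show that the size of the step is the same on both cores, nor that it differs.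

The compounds shown carry only chloro or methyl at this place on the thiophene, which leaves open what a nitrile, an amine or a carboxylic acid would do there. From the compounds shown here alone, whether the step would look the same on a third core also remains open.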